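A few compounds are considered here, and "the series" means these few. Any claim that something is new, unique, unknown or untested is made for them only; others in the source may bear on it.

Compound 1 `COc1ccc(C(F)(F)F)cc1Nc1ncc(C(F)(F)F)c(N2Cc3cccc(N(C)S(C)(=O)=O)c3C2)n1` carries the shared core with a 2-methoxy-5-(trifluoromethyl)phenyl group on a nitrogen on an aromatic ring. In a functional assay on U-87MG ATCC cells for antiproliferative activity against U-87 MG (Homo sapiens), read by spectrophotometry, with a stated time of 2 days (on this read-out higher numbers stand for weaker inhibition of growth and lower numbers for stronger inhibition of growth), compound 1 gives only a limit, > 30000 nM, not a number. Two measured companions share the same core: compound 2 `CC(=O)N1CCN(c2ccc(Nc3ncc(C(F)(F)F)c(N4Cc5cccc(N(C)S(C)(=O)=O)c5C4)n3)cc2)CC1` gives 22100 nM, and compound 3 `CN(c1cccc2c1CN(c1nc(Nc3ccc(Nc4ccccc4)cc3)ncc1C(F)(F)F)C2)S(C)(=O)=O` gives 29800 nM. Those two differ in one place, and the step of a 1.3-fold higher number from compound 2 to compound 3 (0.13 log units; within the scatter) concerns anilino in place of 4-acetylpiperazin-1-yl on an aromatic carbon. Compound 4 `COc1cc(Nc2ncc(C(F)(F)F)c(N3Cc4cccc(N(C)S(C)(=O)=O)c4C3)n2)cc(C(F)(F)F)c1` is yet to be measured. It differs from compound 1 by 3-methoxy-5-(trifluoromethyl)phenyl in place of 2-methoxy-5-(trifluoromethyl)phenyl on a nitrogen on an aromatic ring, the same atoms joined differently. Within the data shown here, no measured step touches this part of the molecule, so the only guide is that all three measured compounds give high numbers, with compound 1 sitting at the limit described by the limit of > 30000 nM in this assay, at which 1 of the 3 values shown sits. A step of a number no higher from compound 1 to compound 4 (the limit leaves the size open) is therefore expected, meaning none beyond the scatter. Compound 4 is estimated at 30000 nM, with a range from 10000 nM to 100000 nM.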

Compound 4, concentration for 50% growth inhibition: > 30000 nM
Compound 4: only a limit was reported; the forecaster's own chance of this, stated with the estimate: 70%; the middle value lies on the limit itself.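

Compound 1 and compound 4 each give only a limit, not a number, so no step between them can be read: the limit of > 30000 nM in this assay, at which 2 of the 4 values shown sit.

The compounds shown leave open whether 3-methoxy-5-(trifluoromethyl)phenyl in place of 2-methoxy-5-(trifluoromethyl)phenyl changes growth inhibition at all.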